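Urotensin-2 receptor efficacy: amide to urea step

A few compounds are considered here, and "the series" means these few. Any claim that something is new, unique, unknown or untested is made for them only; others in the source may bear on it.

Measured so far:
- compound 1, `Cc1ccsc1C(=O)OC(CCN(C)C)c1ccc(Cl)cc1`: 119%
- compound 2, `Cc1ccccc1C(=O)NC(CCN(C)C)c1ccc(Cl)cc1`: 175%
- compound 3, `CN(C)CCC(OC(=O)Nc1ccc(Oc2ccccc2)cc1)c1ccc(Cl)cc1`: 107%

In an assay on NIH3T3 cells with Urotensin-2 receptor (Homo sapiens) as the target (on this read-out lower numbers stand for smaller maximal responses and higher numbers for larger maximal responses), compound 2 gives the highest of the three numbers; the nearest is compound 1 and the furthest is compound 3, and both of those gaps lie beyond the scatter of repeated measurements. Within the data shown here, no pair of measured compounds differs in only one place, so no single step between them can be separated out.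

Compound 4, `CN(C)CCC(NC(=O)NCc1ccccc1)c1ccc(Cl)cc1`, is not yet measured. Relative to compound 2 the change is benzylamino in place of 2-methylphenyl on a carbonyl carbon. It is a fresh change without a parallel among the measured pairs. Given that compound 2 stands alone at the top and the other two compounds sit well below it in this assay, the expectation for the step from compound 2 to compound 4 is a decrease beyond the scatter, a number 55 percentage points lower from compound 2 to compound 4 (beyond the scatter). Compound 4 is therefore estimated at 120%, with a range from 85% to 160%.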

Compound 4, largest response reached (reported as efficacy), in percent of the reference or control that the assay uses: 179%
Compound 4: middle estimate off by 59 percentage points, on the low side; the whole stated range lies below it.
By their numbers in this assay, from the lowest: compound 3; then compound 1; then compounds 2 and 4 (each within the scatter of the next).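

In this assay putting benzylamino in place of 2-methylphenyl on a carbonyl carbon gives a number 4 percentage points higher from compound 2 to compound 4 (within the scatter) and the two compounds cannot be told apart. The entering group brings a nitrogen and a hydrogen-bond donor that 2-methylphenyl lacks, yet the high maximal response seen for compound 2 is also seen for compound 4, so at this position that response is not confined to 2-methylphenyl. No measurement available here bears on why the two groups match.

Still open, from the compounds shown here alone, is whether a group without an aromatic ring, such as methylamino, or a longer chain, such as phenethylamino, would keep this response on the same carbonyl carbon. Compound 1 and compound 3 differ from compound 2 and compound 4 in more than one place, so the role of the amide-type nitrogen itself also remains unresolved.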